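The compounds below may be only part of what the source reports. "The series", "measured", "known", "first", "only" and "open" are said of these compounds alone.

Measured so far in an assay on CHO cells for displacement of a labelled ligand from Substance-P receptor (Homo sapiens); on this read-out higher numbers stand for weaker inhibition and lower numbers for stronger inhibition: compound 1 `CN(C(=O)C(c1ccccc1)c1ccccc1)c1cc(C(F)(F)F)cc(C(F)(F)F)c1` gives 301 nM; compound 2 `O=C(NCCCc1cc(C(F)(F)F)cc(C(F)(F)F)c1)C(c1ccccc1)c1ccccc1` gives 593 nM.

In this assay compound 2 stands alongside compound 1, the two values lying within the usual scatter of each other, so nothing separates them. Compound 3 `CN(CCCc1cc(C(F)(F)F)cc(C(F)(F)F)c1)C(=O)C(c1ccccc1)c1ccccc1` has not been measured in this assay. Its difference from compound 2 is methyl in place of hydrogen on an amide-type nitrogen. Going by the values given here, no step of this kind stands between two measured compounds, so no measured guide exists. Compound 1 already carries a methyl on its amide nitrogen, and compound 1 gives 301 nM, close to compound 2, which suggests the change does little here. The step from compound 2 to compound 3 is therefore expected to be small, a 1.5-fold lower number from compound 2 to compound 3 (0.17 log units; within the scatter), not clearly beyond the scatter. Compound 3 is estimated at 400 nM, with a range from 130 nM to 1200 nM.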

Compound 3, half-maximal inhibitory concentration: 323 nM
For compound 3 the middle estimate is 1.2-fold (0.09 log units) above the measured one, and the stated range covers the measured number.
By their numbers in this assay, from the lowest: compounds 1, 3 and 2 (each within the scatter of the next).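

In this assay, methyl in place of hydrogen on the amide-type nitrogen, whose other neighbours are the carbonyl carbon and a saturated chain carbon, gives a 1.8-fold lower number from compound 2 to compound 3 (0.26 log units; within the scatter). Going by these compounds alone, this is the first direct reading of this change on a matched pair, and it shows that the amide hydrogen can give way to methyl at this nitrogen without a shift that stands clear of the scatter, so compound 2 and compound 3 cannot be told apart here. Nothing available bears on the reason for this outcome.

From the compounds shown here alone, whether an ethyl group, a longer chain or a chain ending in an amine on this nitrogen would also stay within the scatter remains open. A single step also cannot show whether methyl would read the same way on a different core.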